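The source may hold more compounds than are shown below. What is called first, only, known or untested is meant among the compounds shown, and "the series" means these compounds.

Compound 1 `COc1ccc(-c2nc3c(NC4CCCC4)ncnc3n2C)cc1`: 1850 nM
Compound 2 `Cc1ccccc1-c1nc2c(NC3CCCC3)ncnc2n1C`: 3000 nM
Compound 3 `CCCn1c(-c2ccccc2)nc2c(N)ncnc21`: 9280 nM

These three compounds were tested in an assay on CHO cells for displacement of a labelled ligand from adenosine receptor A3 (Homo sapiens), read by scintillation counting, with a stated time of 3 h; a lower number here means a stronger inhibitor, a higher number a weaker inhibitor. Compound 2 stands second highest of the three numbers; its nearest neighbour is compound 1, and the step of a 1.6-fold higher number from compound 1 to compound 2 (0.21 log units; within the scatter) falls within the scatter, while the value of compound 3 lies further off, as a higher number beyond the scatter. Compound 4 `Cc1cccc(-c2nc3c(NC4CCCC4)ncnc3n2C)c1` is the next compound, not yet measured. It differs from compound 2 only in where the methyl sits on the phenyl ring: 3-methylphenyl in place of 2-methylphenyl on an aromatic carbon. For the measured compounds named here, the only measured step that bears on this change is the swap on the same phenyl ring between compound 1 and compound 2, which stayed within the scatter. A step of similar size, not beyond the scatter, is therefore expected in this assay. Compound 4 is estimated at about 2500 nM, with a range from 1000 nM to 6000 nM. For compound 4 this estimate means a step of a 1.2-fold lower number from compound 2 to compound 4 (0.08 log units; within the scatter) from compound 2.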

Compound 4, inhibition constant: 510 nM
The estimate for compound 4 lay 4.9-fold (0.69 log units) above the measured number, outside the stated range (below it).
By their numbers in this assay, from the lowest: compound 4; then compounds 1 and 2 (each within the scatter of the next); then compound 3.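

Moving a single methyl around the phenyl ring matters at this position: in this assay the step of a 5.9-fold lower number from compound 2 to compound 4 (0.77 log units; beyond the scatter) lies beyond the scatter, even though the entering and leaving groups have the same atoms. The 3-methylphenyl group also separates from 4-methoxyphenyl in the step of a 3.6-fold lower number from compound 1 to compound 4 (0.56 log units; beyond the scatter) and so the earlier swap on this ring gave no sign of such a change. Nothing shown explains this difference.

Still open, going by these compounds, is whether an ethyl group or an amine in place of the methyl on the phenyl ring would keep the lower number.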